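Trimming the Benzyl Group: Cytotoxicity of Compound 4

The source may report more compounds than this note shows. Statements on the series, on what has been measured and on what is new or still open speak of the compounds shown alone.

Compound 1, `COc1cc2c(=O)c(C(=O)c3ccc(C)cc3)cn(CC3CCCCC3)c2cc1OC`, in an ADME assay on Huh-7 cells (Homo sapiens) for cytotoxicity (a higher number here means a weaker inhibitor of growth, a lower number a stronger inhibitor of growth), gives 22000 nM.
Compound 2, `COc1cc2c(=O)c(C(=O)c3ccc(C)cc3)cn(Cc3ccc(C(C)C)cc3)c2cc1OC`, gives 15500 nM.
Compound 3, `O=C(OCc1ccc(Cl)cc1)c1cn(Cc2ccc(Cl)cc2)c2cc(N3CCNCC3)c(F)cc2c1=O`, gives 1100 nM.

Compound 2 has the second highest of the three numbers. Its nearest neighbour is compound 1, whose value lies within the scatter of repeated measurements, so the two cannot be told apart. Going by the values given here, compound 3, built on a different core, stands far lower and is the only compound clearly separated from the other two.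

Compound 4, `COc1cc2c(=O)c(C(=O)c3ccc(C)cc3)cn(Cc3ccccc3)c2cc1OC`, is compound 2 with one group removed: hydrogen in place of isopropyl on an aromatic carbon. Among the compounds with values here, only one measured step touches the same region of the molecule, the change of the whole group on the saturated chain carbon bound to the aromatic nitrogen, a 1.4-fold lower number from compound 1 to compound 2 (0.15 log units; within the scatter), which stayed within the scatter. Compound 3 shares no single-change link with compound 2 and offers no guidance here. The expectation is therefore a change of no more than the scatter, in no clear direction.

Compound 4 is estimated at 16000 nM, with a range from 7000 nM to 35000 nM. The step this estimate implies, a 1.0-fold higher number from compound 2 to compound 4 (0.01 log units; within the scatter), is expected to stay within the scatter.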

Compound 4, concentration for 50% growth inhibition: "not active" (no number reported)
No number was reported for compound 4, and the estimate cannot be compared.
By their numbers in this assay, from the lowest: compound 3; then compounds 2 and 1 (each within the scatter of the next).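

Going by these compounds alone, compound 4 is reported in this assay only as "not active", without a number, and no step from compound 2 to compound 4 can be read. No other data here bear on this result. On these data alone, whether losing the isopropyl group moves the number beyond the scatter stays open.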